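Swapping the benzyl group on an inactive pair

This account rests on a few compounds, and the source may have more. Where it says the series, first, only, none or still open, it means among the compounds named here.

In a functional assay on G-361 cells (Homo sapiens) for antiproliferative activity, with a stated time of 72 h (a higher number here means a weaker inhibitor, a lower number a stronger inhibitor), compound 1 `Cc1cccc(CNc2ncnc3c2ncn3[C@@H]2O[C@H](CO)[C@@H](O)[C@H]2O)c1` gives > 166000 nM, which is a limit. Compound 2 `OC[C@H]1O[C@@H](n2cnc3c(NCc4ccc(F)c(Cl)c4)ncnc32)[C@H](O)[C@@H]1O` gives > 166000 nM, also a limit, so it has no readable position, and the evidence is the limit of > 166000 nM in this assay, at which 2 of the 2 values shown sit. Among the measured compounds shown here, the only measured step is a step that the two limits leave unreadable from compound 1 to compound 2, and it offers no size to carry forward. Compound 3 `OC[C@H]1O[C@@H](n2cnc3c(NCc4cccc(O)c4O)ncnc32)[C@H](O)[C@@H]1O` carries 2,3-dihydroxyphenyl in place of 3-chloro-4-fluorophenyl, on a saturated chain carbon bound to a nitrogen on an aromatic ring: 2,3-dihydroxyphenyl in place of 3-chloro-4-fluorophenyl on a saturated chain carbon bound to a nitrogen on an aromatic ring. With no measured size to guide it, a move toward a lower number is expected only tentatively, and another limit remains quite possible. The expected change is an at least 4.1-fold lower number from compound 2 to compound 3 (0.61 log units; beyond the scatter). For compound 3 the estimated value is 40000 nM, with an expected range of 4000 nM to 166000 nM.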

Compound 3, half-maximal inhibitory concentration: 16900 nM
Compound 3: middle estimate off by 2.4-fold (0.37 log units), on the high side; the range from low to high includes it.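

In this assay, the group on this saturated chain carbon proves able to move the read-out: 2,3-dihydroxyphenyl in place of 3-chloro-4-fluorophenyl gives an at least 9.8-fold lower number from compound 2 to compound 3 (0.99 log units; beyond the scatter), and in place of 3-methylphenyl it gives an at least 9.8-fold lower number from compound 1 to compound 3 (0.99 log units; beyond the scatter). Among the compounds shown here, compound 3 is the first compound here with a readable value, while the step between the two earlier compounds cannot be read. Both new sizes are only lower bounds because the two earlier compounds rest on a limit: the limit of > 166000 nM in this assay, at which 2 of the 3 values shown sit.

The compounds shown leave open how large these steps truly are. They also leave open whether a single hydroxyl group, an amine or a carboxylic acid on the phenyl ring would give a readable value too.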